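A few compounds are considered here, and "the series" means these few. Any claim that something is new, unique, unknown or untested is made for them only; others in the source may bear on it.

Measured so far:
compound 1, `O=C(Nc1cccc(-n2cc(-c3ccncc3)c(-c3ccc(Cl)c(O)c3)n2)c1)Nc1cccc(C(F)(F)F)c1` — > 32500 nM
compound 2, `COc1cc(-c2nn(-c3cccc(NC(=O)Nc4cc(C(F)(F)F)cc(C(F)(F)F)c4)c3)cc2-c2ccncc2)ccc1Cl` — 4330 nM
compound 3, `COc1cc(-c2nn(-c3cccc(NC(=O)Nc4cccc(C(F)(F)F)c4)c3)cc2-c2ccncc2)ccc1Cl` — 50000 nM

The three measured compounds share one core and differ only in the urea end. In a functional assay on HCT-15 cells (Homo sapiens) for inhibition, read by sulforhodamine B assay, with a stated time of 48 h (a higher number here means that more compound is tolerated, a lower number that less compound is tolerated), compound 3 gives 50000 nM, the highest of the two numbers recorded. Compound 2 is nearest: a 12-fold higher number from compound 2 to compound 3 (1.06 log units; beyond the scatter). For compound 1 the assay reports only a limit, > 32500 nM; the step from compound 1 to compound 3 is therefore unreadable, a step that the limit leaves unreadable from compound 1 to compound 3.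

Compound 4, `COc1cc(-c2nn(-c3cccc(NC(=O)c4ccccc4)c3)cc2-c2ccncc2)ccc1Cl`, is not yet measured. It differs from compound 3 in one place: phenyl in place of (3-(trifluoromethyl)phenyl)amino on a carbonyl carbon. The urea becomes a benzamide and the trifluoromethyl is lost.

Of the measured steps, only the removal of a trifluoromethyl from the urea aryl, a 12-fold higher number from compound 2 to compound 3 (1.06 log units; beyond the scatter), bears on this change, and it was large and upward. The step to compound 4 removes the last trifluoromethyl together with one amide nitrogen, a larger change than any measured here. The expected direction in this assay is therefore upward or flat, a 1.2-fold higher number from compound 3 to compound 4 (0.08 log units; within the scatter), with a real chance that only a limit is reported. The expected value for compound 4 is 60000 nM, within 20000 nM to 200000 nM.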

Compound 4, concentration lethal to 50% of the cells: > 100000 nM
Compound 4: no number, only a limit; the forecaster's own chance of this, stated with the estimate: 50%; middle value at least 1.6-fold (0.22 log units) away from the limit.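

In this assay, phenyl in place of (3-(trifluoromethyl)phenyl)amino on the carbonyl carbon gives an at least 2.0-fold higher number from compound 3 to compound 4 (0.30 log units; that floor lies within the scatter). This is the first change shown at the urea itself rather than on its aryl end, and the benzamide of compound 4 shows no drop in the number compared with the urea of compound 3. The result for compound 4 is only a limit, so the true size of the step cannot be read and its floor does not pass the scatter: the limit of > 100000 nM in this assay, at which 1 of the 4 values shown sits.

Compound 4 loses the trifluoromethyl and the urea nitrogen together, so the compounds shown do not separate the two changes. Also open, going by these compounds, is whether an amine or a carboxylic acid on the phenyl of the benzamide would bring the number down into a readable range.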